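Isopropyl to tert-butyl: one added methyl

A few compounds are considered here, and "the series" means these few. Any claim that something is new, unique, unknown or untested is made for them only; others in the source may bear on it.

Compound 1 `COc1ccc(/C=C/c2cc(OC)c(OC(C)=O)c(OC)c2)cc1` gives 10.2 uM
Compound 2 `COc1cc(/C=C/c2ccc(C(C)C)cc2)cc(OC)c1OC` gives 11.1 uM
Compound 3 `COC(=O)C(Cc1cc(OC)c(OC)c(OC)c1)c1ccc(OC)cc1` gives > 25 uM as a limit, not a number

All three compounds were tested in a functional assay on SK-MEL-5 cells (Homo sapiens) for cytotoxicity (a higher number here means that more compound is needed for the effect, a lower number that less compound is needed), and compound 2 stands level with compound 1: compound 2 at 11.1 uM and compound 1 at 10.2 uM lie within the usual scatter of each other. Compound 3 gives > 25 uM as its result, which is a limit of the assay.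

Compound 4 `COc1cc(/C=C/c2ccc(C(C)(C)C)cc2)cc(OC)c1OC` has not yet been measured. It departs from compound 2 by one small change methyl in place of hydrogen on a saturated chain carbon bound to an aromatic carbon and two saturated chain carbons in which methyl takes the place of hydrogen, so that isopropyl becomes tert-butyl.

Among the compounds with values here, no measured pair here differs in only one place, so the data do not show directly what such a change does. Starting from compound 2 at 11.1 uM as the reference, no step beyond the scatter is expected in this assay for so small a change. The expected change is a 1.1-fold lower number from compound 2 to compound 4 (0.05 log units; within the scatter) and this estimate stays within the scatter. Compound 4 is estimated at 10 uM with a range from 4.5 uM to 24 uM as the expected spread.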

Compound 4, concentration for half-maximal effect: > 25 uM
Compound 4 gave a limit, no number; the forecaster's own chance of this, stated with the estimate: 15%; at least 2.5-fold (0.39 log units) between middle value and limit.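

Compounds 2 and 4 differ in only one place, so the effect of a single change can now be read directly: in this assay, the change from isopropyl to tert-butyl gives an at least 2.2-fold higher number from compound 2 to compound 4 (0.35 log units; beyond the scatter). One added methyl on this saturated chain carbon is thus enough to raise the amount of compound needed for the effect beyond the scatter. Compound 4 gives a limit, not a number, so the step shows only its smallest possible size: the limit of > 25 uM in this assay, at which 2 of the 4 values shown sit.

The compounds shown leave open what ethyl or cyclopropyl would give in place of isopropyl, and so whether any other group here keeps the number of compound 2. They also leave open what a hydroxyl or an amine would do in place of the hydrogen on this carbon.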